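A few compounds are considered here, and "the series" means these few. Any claim that something is new, unique, unknown or untested is made for them only; others in the source may bear on it.

In a functional assay on U-87MG ATCC cells for antiproliferative activity against U-87 MG (Homo sapiens), read by spectrophotometry, with a stated time of 2 days (a higher number here means a weaker inhibitor of growth, a lower number a stronger inhibitor of growth), compound 1 (`CN(c1cccc2c1CN(c1nc(Nc3cccc(Oc4ccccc4)c3)ncc1C(F)(F)F)C2)S(C)(=O)=O`) gives 19500 nM. Compound 2 (`CN(c1cccc2c1CN(c1nc(Nc3ccc(C(F)(F)F)cc3)ncc1C(F)(F)F)C2)S(C)(=O)=O`) gives > 30000 nM, which is a limit and not a number. Compound 3 (`COc1cc(Nc2ncc(C(F)(F)F)c(N3Cc4cccc(N(C)S(C)(=O)=O)c4C3)n2)cc(OC)c1`) gives > 30000 nM, also a limit, and this places it at the limit of > 30000 nM in this assay, at which 2 of the 3 values shown sit. Compound 4 (`CN(c1cccc2c1CN(c1nc(Nc3cccc(C(F)(F)F)c3)ncc1C(F)(F)F)C2)S(C)(=O)=O`) carries 3-(trifluoromethyl)phenyl in place of 3,5-dimethoxyphenyl on a nitrogen on an aromatic ring. For the measured compounds named here, the only measured step at this place, a step that the two limits leave unreadable from compound 2 to compound 3, has no readable size, so it gives no size to carry over. The closest guide is compound 2, which also bears trifluoromethyl on its phenyl ring and reads > 30000 nM, again a limit. The expected change is a number no higher from compound 3 to compound 4 (the limit leaves the size open) in this assay, no larger than the scatter and with no clear direction. Compound 4 is estimated at 30000 nM, with an expected range from 15000 nM to 60000 nM.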

Compound 4, concentration for 50% growth inhibition: > 30000 nM
Compound 4: a limit, no number; the forecaster's own chance of this, stated with the estimate: 65%; the middle value lies on the limit itself.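

In this assay, 3-(trifluoromethyl)phenyl on this nitrogen also gives only a limit and no number, so compound 4 joins the compounds at the ceiling: the limit of > 30000 nM in this assay, at which 3 of the 4 values shown sit.

The steps among compound 2, compound 3 and compound 4 cannot be read, so these three groups cannot be ranked. Trifluoromethyl in place of phenoxy gives an at least 1.5-fold higher number from compound 1 to compound 4 (0.18 log units; that floor lies within the scatter), which alone does not establish a real loss.

Going by these compounds, how far compound 2, compound 3 and compound 4 lie beyond the limit stays open. So does whether an amine or a carboxylic acid on this phenyl ring would give a readable number.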